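From Selenium to Methylsulfanyl: Expecting Another Weak Compound

The source may hold more compounds than are shown below. What is called first, only, known or untested is meant among the compounds shown, and "the series" means these compounds.

Compound 3 `[SeH]c1nc(NCc2ccccc2)c2ccccc2n1` is one of three analogues tested in a functional assay on HTB-54 cells (Homo sapiens) for cytotoxicity, read by MTT assay, with a stated time of 72 h; a higher number here means a weaker inhibitor of growth, a lower number a stronger inhibitor of growth. In this assay compound 3 reaches only the limit > 100000 nM, which is not a number but the boundary of the measurement. Compound 2 `Sc1nc(NCc2ccccc2)c2ccccc2n1`, the sulfur counterpart, also sits at the limit > 100000 nM in this assay. Going by the values given here, compound 1 `COc1ccc(CNc2nc([SeH])nc3ccccc23)cc1`, which carries a methoxy group, is the only one with a measured number, giving 60900 nM in this assay. The step of an at least 1.6-fold higher number from compound 1 to compound 3 (0.21 log units; that floor lies within the scatter) therefore rests on one limit, and the step that the two limits leave unreadable from compound 2 to compound 3 rests on two, so neither fixes compound 3 beyond showing it to be a weak inhibitor of growth. Compound 4 `CSc1nc(NCc2ccccc2)c2ccccc2n1` is not yet measured; it differs from compound 3 by a group of 2 heavy atoms (1 carbon, 1 sulfur; no ring) in place of one selenium atom, on an aromatic carbon. Among the compounds with values here, no measured step swaps selenium for a methylsulfanyl group, and the nearest comparison, a step that the two limits leave unreadable from compound 2 to compound 3, is unreadable, so no direction can be taken from the data. Since the limit of > 100000 nM in this assay, at which 2 of the 3 values shown sit, describes most of the values, compound 4 is expected to sit near that same boundary, and the step of a number no higher from compound 3 to compound 4 (the limit leaves the size open) is expected to remain within the scatter. The estimate for compound 4 in this assay is 100000 nM, within a range from 40000 nM to 300000 nM.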

Compound 4, concentration for total growth inhibition: 82300 nM
The estimate for compound 4 lay 1.2-fold (0.08 log units) above the measured number; the measured number falls inside the stated range.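

In this assay, going by these compounds alone, compound 4 gives 82300 nM, the first measured number at this position, between two ring nitrogen atoms, for the core shared by compound 2, compound 3 and compound 4. From the compounds shown here alone, the change from selenium to methylsulfanyl reads as an at least 1.2-fold lower number from compound 3 to compound 4 (0.08 log units; that floor lies within the scatter), and placing methyl on the sulfur reads as an at least 1.2-fold lower number from compound 2 to compound 4 (0.08 log units; that floor lies within the scatter); both are only floors, so the true size of each step stays open and neither shows a change beyond the scatter. Methylsulfanyl at this position therefore leaves a weak inhibitor of growth, and the boundary of the measurement still limits every comparison with the unmethylated compounds: the limit of > 100000 nM in this assay, at which 2 of the 4 values shown sit.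

The step between compound 2 and compound 3 cannot be read, so selenium and sulfur stay unranked at this position. Going by these compounds, whether a longer chain on the sulfur, such as ethylsulfanyl, or an amine at this position would move the number beyond the scatter remains open, as does the effect of pairing methylsulfanyl with the methoxy group of compound 1.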